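A Chloro Substituent Added to the Fluorophenyl Ring of Compound 1

The source may hold more compounds than are shown below. What is called first, only, known or untested is meant among the compounds shown, and "the series" means these compounds.

Measured compounds:
Compound 1, `CCOC(=O)C1=Cc2ccccc2OC1(OCc1cn(-c2ccc(F)cc2)nn1)C(F)(F)F`, gives 9100 nM in a functional assay on MCF7 cells (Homo sapiens) for inhibition, read by MTT assay, with a stated time of 24 h; a higher number here means a weaker inhibitor, a lower number a stronger inhibitor.
Compound 2, `O=C(O)C1=Cc2ccccc2OC1(OCc1cc(-c2ccc3ccccc3c2)no1)C(F)(F)F`, gives > 150000 nM in this assay, a limit of the assay rather than a number.
Compound 3, `O=C(O)C1=Cc2ccccc2OC1(OCc1cc(-c2ccc(F)cc2)no1)C(F)(F)F`, gives 64200 nM in this assay.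

Of the two numbers available, compound 1 stands lowest, so it is the stronger inhibitor of the pair; compound 3 sits clearly higher. For compound 2 only a limit is known.

Compound 4, `CCOC(=O)C1=Cc2ccccc2OC1(OCc1cn(-c2ccc(F)c(Cl)c2)nn1)C(F)(F)F`, differs from compound 1 by chloro in place of hydrogen on an aromatic carbon. Among the measured compounds shown here, the only measured step, an at least 2.3-fold lower number from compound 2 to compound 3 (0.36 log units; beyond the scatter), exchanges one whole aryl group for another on a different core series, and so does not bear directly on adding a chloro group to a 4-fluorophenyl ring that is kept. For the measured compounds named here, with no measured step of the same kind, no change beyond the scatter is expected in this assay. The step from compound 1 is therefore estimated at a 1.2-fold lower number from compound 1 to compound 4 (0.08 log units; within the scatter). Compound 4 is expected to give about 7500 nM, within a range from 3000 nM to 20000 nM.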

Compound 4, half-maximal inhibitory concentration: 25300 nM
The estimate for compound 4 lay 3.4-fold (0.53 log units) below the measured number; measured number above the stated range.
By their numbers in this assay, from the lowest: compound 1; then compound 4; then compound 3. At a limit, above all of these: compound 2.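

The step in this assay reads a 2.8-fold higher number from compound 1 to compound 4 (0.44 log units; beyond the scatter), so the change from 4-fluorophenyl to 3-chloro-4-fluorophenyl moves the number beyond the scatter, towards a weaker inhibitor. The earlier compounds shown here showed only an exchange of one whole aryl group for another, whereas this pair shows that, with the 4-fluorophenyl ring kept, this position ortho to the fluoro group is not indifferent to substitution. Nothing in the data shown bears on the cause of this loss.

Chloro is the only group shown at this position, so it remains open whether a methoxy group, a nitrile or an amine there would give a similar loss. On these data alone, whether the step would hold with a carboxylic acid in place of the ethyl ester also remains open.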